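This account rests on a few compounds, and the source may have more. Where it says the series, first, only, none or still open, it means among the compounds named here.

For the measured compounds named here, compound 2 `O=C(CSc1nnc(-c2ccncc2)o1)N/N=C/c1ccccc1[N+](=O)[O-]` gives 35600 nM in a functional assay on MCF7 cells (Homo sapiens) for cytotoxicity, read by MTT assay, with a stated time of 48 h (on this read-out lower numbers stand for stronger inhibition and higher numbers for weaker inhibition), the highest of the two numbers so far; compound 1 `O=C(CSc1nnc(-c2ccncc2)o1)N/N=C/c1ccc(Cl)cc1` gives 15300 nM, and a 2.3-fold higher number from compound 1 to compound 2 (0.37 log units; beyond the scatter) is the only measured step at this position. Compound 3 `O=C(CSc1nnc(-c2ccncc2)o1)N/N=C/c1cc(Br)cc(Br)c1O` carries 3,5-dibromo-2-hydroxyphenyl in place of 2-nitrophenyl on a carbon with a double bond to nitrogen. Going by the values given here, that earlier step bears on it only as a sign that exchanging the aryl group moved this assay modestly; no measured step covers the entering group. A modest step of uncertain direction is therefore expected, a 1.6-fold lower number from compound 2 to compound 3 (0.21 log units; within the scatter). Compound 3 is estimated at 22000 nM, within a range from 6000 nM to 70000 nM.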

Compound 3, half-maximal inhibitory concentration: 9010 nM
Compound 3: the middle estimate sits 2.4-fold (0.39 log units) above what was measured, within the range that was stated.
By their numbers in this assay, from the lowest: compounds 3 and 1 (each within the scatter of the next); then compound 2.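

In this assay, replacing 2-nitrophenyl with 3,5-dibromo-2-hydroxyphenyl on a carbon with a double bond to nitrogen gives a 4.0-fold lower number from compound 2 to compound 3 (0.60 log units; beyond the scatter), a second step beyond the scatter at this position. Exchanging 4-chlorophenyl for the same group gives a 1.7-fold lower number from compound 1 to compound 3 (0.23 log units; within the scatter), so 2-nitrophenyl alone stands apart among these three aryl groups. No evidence is available to explain this difference.

The compounds shown do not separate the contribution of the two bromine atoms from that of the hydroxy group. As far as these compounds go, whether an amine or a carboxylic acid on this aryl ring would be tolerated remains open.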